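Acylating the Amine of Compound 2

This account rests on a few compounds, and the source may have more. Where it says the series, first, only, none or still open, it means among the compounds named here.

Compound 2 `Nc1nc(-c2ccccc2)nc2c1nnn2Cc1ccccc1` carries a free amine on its core. For the measured compounds named here, in an assay (strain Wistar) for displacement of a labelled ligand from adenosine receptor A1 (Rattus norvegicus), read by scintillation counting (a higher number here means a weaker inhibitor, a lower number a stronger inhibitor), compound 2 gives 5.6 nM, the lowest of the two numbers measured so far. Compound 1 `O=C(Nc1nc(-c2ccccc2)nc2c1nnn2Cc1ccccc1)c1ccccc1C(F)(F)F` bears an amide in place of that amine; in this assay compound 1 gives 550 nM, a far higher number, well beyond the scatter of repeated measurements. Compound 3 `Cc1ccc(C(=O)Nc2nc(-c3ccccc3)nc3c2nnn3Cc2ccccc2)cc1` has not yet been measured. Going by the values given here, it differs from compound 2 by (4-methylphenyl)carbonyl in place of hydrogen on a nitrogen on an aromatic ring, so compound 3 is also an amide, with a different aryl group from the one in compound 1. Capping the amine in compound 1 went along with a much weaker result than compound 2 shows, and the same direction is expected here. For compound 3, the step of a 36-fold higher number from compound 2 to compound 3 (1.55 log units; beyond the scatter) is expected to be a clear rise, beyond the scatter. The estimate for compound 3 in this assay is 200 nM, within a range from 40 nM to 1000 nM.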

Compound 3, inhibition constant: 709 nM
Estimate against measurement, compound 3: 3.5-fold (0.55 log units) below, and the stated range covers the measured number.
By their numbers in this assay, from the lowest: compound 2; then compounds 1 and 3 (each within the scatter of the next).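

In this assay, putting (4-methylphenyl)carbonyl on the amine gives a 130-fold higher number from compound 2 to compound 3 (2.10 log units; beyond the scatter) and so provides a second amide on this nitrogen with a much higher number than the free amine. The aryl group on the carbonyl makes no readable difference between these two amides: 4-methylphenyl in place of 2-(trifluoromethyl)phenyl gives a 1.3-fold higher number from compound 1 to compound 3 (0.11 log units; within the scatter) so the large rise goes with the amide itself and not with one particular aryl group. Nothing available explains why the amide goes with this rise.

Still open, from the compounds shown here alone, is whether the aryl ring matters at all, or whether a small acetyl group on this nitrogen would give a number closer to that of compound 2. A methyl group on the nitrogen, with no carbonyl, would raise the same question for the carbonyl.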